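Smaller aryl group on a thiophene-based reductase inhibitor

This account rests on a few compounds, and the source may have more. Where it says the series, first, only, none or still open, it means among the compounds named here.

Measured compounds:
- compound 1 `CC(C)=Cc1c(-c2ccccc2)sc(C(C)C)c1/C=C/[C@@H](O)C[C@@H](O)CC(=O)O` gives 1000 nM
- compound 2 `CC(C)c1sc(-c2ccccc2)c(C2CCCC2)c1/C=C/[C@@H](O)C[C@@H](O)CC(=O)O` gives 417 nM
- compound 3 `CC(C)c1sc(-c2ccccc2)c(-c2cccc(C(F)(F)F)c2)c1/C=C/[C@@H](O)C[C@@H](O)CC(=O)O` gives 2980 nM

These three share one core and differ only in a single group on an aromatic carbon. In an assay on microsomes for inhibition of 3-hydroxy-3-methylglutaryl-coenzyme A reductase (Rattus norvegicus) (on this read-out higher numbers stand for weaker inhibition and lower numbers for stronger inhibition), compound 3 gives the highest number of the three: the step from compound 1 to compound 3 is a 3.0-fold higher number from compound 1 to compound 3 (0.47 log units; beyond the scatter), and the step from compound 2 to compound 3 is a 7.1-fold higher number from compound 2 to compound 3 (0.85 log units; beyond the scatter). Both changes replace a non-aromatic group with 3-(trifluoromethyl)phenyl, and both weaken inhibition.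

Compound 4 `CC(C)c1sc(-c2ccccc2)c(-c2ccccc2F)c1/C=C/[C@@H](O)C[C@@H](O)CC(=O)O` is not yet measured. It differs from compound 3 as follows: 2-fluorophenyl in place of 3-(trifluoromethyl)phenyl on an aromatic carbon. For the measured compounds named here, no measured step compares one aryl group with another, so the earlier steps bear on this change only loosely. A smaller aryl group moves the structure part of the way back toward compounds 1 and 2, so a modest gain is expected, with the number for compound 4 estimated to fall by a 1.7-fold lower number from compound 3 to compound 4 (0.22 log units; within the scatter). The expected value for compound 4 in this assay is 1800 nM, between 600 nM and 5000 nM.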

Compound 4, half-maximal inhibitory concentration: 233 nM
Compound 4: the middle estimate sits 7.7-fold (0.89 log units) above what was measured, outside the stated range (below it).
By their numbers in this assay, from the lowest: compounds 4 and 2 (each within the scatter of the next); then compound 1; then compound 3.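

Within this assay the swap of one aryl group for another at this position moves the number further than any earlier step (a 13-fold lower number from compound 3 to compound 4 (1.11 log units; beyond the scatter)), so an aromatic ring here does not by itself weaken inhibition. The 2-fluorophenyl group and the non-aromatic cyclopentyl group differ only within the scatter (a 1.8-fold lower number from compound 2 to compound 4 (0.25 log units; within the scatter)), while the 2-fluorophenyl group clearly outperforms 2-methylprop-1-en-1-yl (a 4.3-fold lower number from compound 1 to compound 4 (0.63 log units; beyond the scatter)), so the weak result of compound 3 belongs to 3-(trifluoromethyl)phenyl and not to aryl groups as a whole. Nothing available explains why these two aryl groups differ so widely.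

These two groups differ in both the substituent and its place on the ring, so the compounds shown cannot tell which of the two matters. As far as these compounds go, whether plain phenyl, 3-fluorophenyl or 2-(trifluoromethyl)phenyl here would fall nearer compound 3 or compound 4 remains open.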